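The source may hold more compounds than are shown below. What is called first, only, known or untested is meant among the compounds shown, and "the series" means these compounds.

Measured so far in an in vitro functional assay on SH-EP1 cells for agonist activity at Neuronal acetylcholine receptor; alpha4/beta2 (Homo sapiens), read by voltage clamp; a lower number here means that less compound is needed, a higher number that more compound is needed for the effect:
compound 1 `C1=C(c2cccnc2)C[C@@H]2CNC[C@H]1C2`: 50 nM
compound 2 `CN1C[C@@H]2C=C(c3cccnc3)C[C@@H](C2)C1`: 3100 nM
compound 3 `CC(C)Oc1cncc(C2=CC3CNCC(C2)C3)c1`: 1400 nM

Compound 1 carries the lowest number of the three, and its steps to the other two are both beyond the scatter. Within the data shown here, the one structural change that occurs twice is methyl in place of hydrogen on an amine nitrogen in a ring; measured once, as a 62-fold higher number from compound 1 to compound 2 (1.79 log units; beyond the scatter), it is a large step upward. Compound 3 differs from compound 1 in more than one place, and the difference between the two cores is not broken down here. In this assay compound 3 gives 1400 nM, a higher number than compound 1 and a lower one than compound 2.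

Compound 4 `CC(C)Oc1cncc(C2=CC3CC(C2)CN(C)C3)c1` is not yet measured. It stands to compound 3 as compound 2 stands to compound 1: methyl in place of hydrogen on an amine nitrogen in a ring, at the same place in the same kind of ring system. Only one earlier instance of this change exists, on a different core, so whether it carries over to compound 3 is not shown. Taking a 62-fold higher number from compound 1 to compound 2 (1.79 log units; beyond the scatter) as the only guide, the step of a 29-fold higher number from compound 3 to compound 4 (1.46 log units; beyond the scatter) is expected, with a wide range. In this assay compound 4 is therefore estimated at 40000 nM, somewhere between 8000 nM and 200000 nM.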

Compound 4, half-maximal effective concentration: 3500 nM
Compound 4: middle estimate off by 11-fold (1.06 log units), on the high side; measured number outside the range, below it.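

In this assay the step for methyl in place of hydrogen on an amine nitrogen in a ring comes out as a 2.5-fold higher number from compound 3 to compound 4 (0.40 log units; beyond the scatter) and so points the same way as on the core of compound 1. The direction of the change therefore holds on both cores shown, but its size does not carry from one core to the other: the same change on two cores in this assay, a 62-fold higher number (1.79 log units; beyond the scatter) from compound 1 to compound 2 and a 2.5-fold higher number (0.40 log units; beyond the scatter) from compound 3 to compound 4, 25-fold (1.39 log units) apart, beyond the scatter of two such steps
These two pairs do not show which difference between the cores goes with the smaller step, as compound 1 and compound 3 differ in more than one place, and they give no size to expect on a third core.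

Still open, from the compounds shown here alone, is whether ethyl or a longer chain on the amine nitrogen would follow the methyl step on either core. Also open, going by these compounds, is whether the size of the step would shift again with a methoxy group or an amine in place of the isopropoxy group of compound 3.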